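The source may report more compounds than this note shows. Statements on the series, on what has been measured and on what is new or still open speak of the compounds shown alone.

Compound 1 `Cc1ccc(C(=O)Nc2ccc3nc(NC(=O)C4CCCCC4)sc3c2)cc1` gives 5.1 ug/mL in a functional assay on WI-38 VA13 cells (Homo sapiens) for cytotoxicity; on this read-out lower numbers stand for an effect already at smaller amounts and higher numbers for an effect only at larger amounts of compound.
Compound 2 `O=C(Nc1ccc2nc(NC(=O)C3CCCCC3)sc2c1)c1c(Cl)cccc1Cl` gives 0.015 ug/mL in this assay.

For the measured compounds named here, compound 2 carries the lowest of the two numbers, and the single measured step, a 340-fold lower number from compound 1 to compound 2 (2.53 log units; beyond the scatter), leads to it. Compound 3 `CCNC(=O)Nc1nc2ccc(NC(=O)c3c(Cl)cccc3Cl)cc2s1` differs from compound 2 by ethylamino in place of cyclohexyl on a carbonyl carbon. Going by the values given here, that measured step concerned the other carbonyl carbon of the shared core, so no measured step bears on the change made here, and neither direction nor size of the step in this assay can be read from the data. Compound 3 is therefore estimated at 0.05 ug/mL, with a wide range from 0.005 ug/mL to 0.5 ug/mL, which corresponds to an expected step of a 3.3-fold higher number from compound 2 to compound 3 (0.52 log units; beyond the scatter).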

Compound 3, half-maximal effective concentration: 0.032 ug/mL
Estimate against measurement, compound 3: 1.6-fold (0.19 log units) above; low and high end bracket the measured number.
By their numbers in this assay, from the lowest: compound 2; then compound 3; then compound 1.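

At the carbonyl carbon whose other neighbour is the amide-type nitrogen, replacing cyclohexyl with ethylamino in this assay gives a 2.1-fold higher number from compound 2 to compound 3 (0.33 log units; beyond the scatter), a modest step though beyond the scatter. This step is much smaller than a 340-fold lower number from compound 1 to compound 2 (2.53 log units; beyond the scatter), which was made at the other carbonyl carbon, so this position accepts the loss of the carbon ring and the entry of a hydrogen-bond donor with little change. No evidence at hand accounts for the step.

As far as these compounds go, the change swaps ring and nitrogen together, and how much each contributes stays open. From the compounds shown here alone, an ethyl group without the nitrogen, or a cyclohexylamino group, would separate the two, and a longer chain or a carboxylic acid at this place remains untested here.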